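The source may hold more compounds than are shown below. What is called first, only, known or untested is meant among the compounds shown, and "the series" means these compounds.

Measured in a functional assay on SMMC-7721 cells (Homo sapiens) for antiproliferative activity, read by MTT assay, with a stated time of 72 h; on this read-out higher numbers stand for weaker inhibition and lower numbers for stronger inhibition:
compound 1 `Cc1nn(C)c(Oc2ccc(Cl)cc2)c1/C=N\CCCCCOc1cc2oc(=O)cc(C)c2cc1Cl`, 17500 nM.
compound 2 `Cc1nn(C)c(Oc2ccc(F)c(F)c2)c1/C=N\CCCCCCOc1cc2oc(=O)cc(C)c2cc1Cl`, reported as a limit only, > 25000 nM.

Compound 2 stands at the edge of what this assay resolves: its value is a limit of the assay and not a number, and (the limit of > 25000 nM in this assay, at which 1 of the 2 values shown sits). Going by the values given here, compound 1 is the only member of the pair with a measured number, and that number is itself high. Among the compounds with values here, no step between measured compounds is available for this series, so nothing within the data says how the aryl group on the oxygen moves potency.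

Compound 3 `Cc1nn(C)c(Oc2cccc(C(F)(F)F)c2)c1/C=N\CCCCCCOc1cc2oc(=O)cc(C)c2cc1Cl`, not yet measured, differs from compound 2 by 3-(trifluoromethyl)phenyl in place of 3,4-difluorophenyl on an oxygen on an aromatic ring. With compound 2 sitting at the limit, the step from compound 2 to compound 3 is expected to be none beyond the scatter, a number no higher from compound 2 to compound 3 (the limit leaves the size open). Compound 3 is therefore estimated at 25000 nM, in the range 12000 nM to 60000 nM, with a fair chance that this assay again returns only a limit for compound 3.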

Compound 3, half-maximal inhibitory concentration: 24800 nM
For compound 3 the middle estimate is 1.0-fold (0.00 log units) above the measured one; measured number inside the range.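

With 3-(trifluoromethyl)phenyl in place of 3,4-difluorophenyl on an oxygen on an aromatic ring, this assay shows a number no higher from compound 2 to compound 3 (the limit leaves the size open). Compound 3 returns a number, 24800 nM, so this change gives a value the read-out can resolve, though that value remains high. For compound 2 the same assay gives only a limit and not a number, > 25000 nM. The size of the step between these two compounds cannot be read, because one side of it is a limit: the limit of > 25000 nM in this assay, at which 1 of the 3 values shown sits.

The compounds shown leave open whether an amine or a carboxylic acid at this place on the oxygen, in place of the substituted phenyl, would bring a number well clear of that limit. They also leave open what a longer chain would do with this 3-(trifluoromethyl)phenyl group held fixed.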